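Chain-stereocentre inversion in the chromane-ether hexynoic acid pair

This account rests on a few compounds, and the source may have more. Where it says the series, first, only, none or still open, it means among the compounds named here.

Measured so far: compound 1 `CC#C[C@H](CC(=O)O)c1ccc(OC[C@H]2COc3ccc(Cl)cc3O2)cc1`, 3400 nM; compound 2 `CC#C[C@H](CC(=O)O)c1ccc(OC[C@@H]2COc3ccc(Cl)cc3O2)cc1`, 5040 nM.

Compound 1 and compound 2 are both measured in a functional assay on HEK293 cells for agonist activity at Free fatty acid receptor 1 (Homo sapiens), read by fluorescence and calcium flux, with a stated time of 10 min; a lower number here means that less compound is needed, a higher number that more compound is needed for the effect; compound 1 gives 3400 nM and compound 2 gives 5040 nM. Compound 2 stands as the higher of the two numbers, but the step of a 1.5-fold higher number from compound 1 to compound 2 (0.17 log units; within the scatter) lies within the scatter, so no ordering between the two can be stated. That step rests only on (the fact that compounds 1 and 2 differ only in the configuration as drawn), and the configurational change there sits at the ring carbon.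

Compound 3 `CC#C[C@@H](CC(=O)O)c1ccc(OC[C@@H]2COc3ccc(Cl)cc3O2)cc1` differs from compound 2 as follows: the two compounds have the same atoms and bonds and differ only in configuration as drawn: 1 of 2 stereo elements differ; a stereocentre at a saturated chain carbon is drawn R in compound 2 and S in compound 3. Going by the values given here, no measured step touches the chain stereocentre; the only measured configurational change, at the ring carbon, gave a step within the scatter. What the chain stereocentre does is therefore unknown from these data, and the step of a 2.4-fold higher number from compound 2 to compound 3 (0.38 log units; beyond the scatter) in this assay is an expectation with a wide range rather than a prediction of a direction. Compound 3 is estimated at 12000 nM, between 2500 nM and 60000 nM.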

Compound 3, half-maximal effective concentration: 260 nM
The estimate for compound 3 lay 46-fold (1.66 log units) above the measured number; the whole stated range lies above it.
By their numbers in this assay, from the lowest: compound 3; then compounds 1 and 2 (each within the scatter of the next).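

Drawing the chain carbon S rather than R gives a 19-fold lower number from compound 2 to compound 3 (1.29 log units; beyond the scatter) in this assay, so this is the first stereocentre in the series shown to matter in this assay. The step can be assigned to that carbon alone, because no other feature changes: the fact that compounds 2 and 3 differ only in the configuration as drawn. With both stereocentres inverted, the mirror-image pair gives a 13-fold lower number from compound 1 to compound 3 (1.12 log units; beyond the scatter), while inversion at the ring carbon alone gave a 1.5-fold higher number from compound 1 to compound 2 (0.17 log units; within the scatter), so among these compounds the large differences appear only where the chain carbon is drawn S.

On these data alone, the ring-carbon inversion has been read only with the chain carbon drawn R, so whether that carbon matters when the chain carbon is drawn S remains open. Also open, as far as these compounds go, is whether the preference for S at the chain carbon holds when a cyclopropyl group replaces the alkyne on that carbon, since every compound here carries the same alkyne.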